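The source may hold more compounds than are shown below. What is called first, only, known or untested is meant among the compounds shown, and "the series" means these compounds.

For the measured compounds named here, compound 2 `O=C(/C=C/C(=O)N1C/C(=C\c2ccc([N+](=O)[O-])cc2)C(=O)/C(=C/c2ccc([N+](=O)[O-])cc2)C1)Nc1ccc(Cl)c(Cl)c1` shows the lowest number so far in a functional assay on CCRF-CEM cells (Homo sapiens) for cytotoxicity (a lower number here means a stronger inhibitor, a higher number a weaker inhibitor), where compound 2 gives 380 nM; its only neighbour, compound 1 `COc1ccc(NC(=O)/C=C/C(=O)N2C/C(=C\c3ccc([N+](=O)[O-])cc3)C(=O)/C(=C/c3ccc([N+](=O)[O-])cc3)C2)cc1`, gives 760 nM, and the step of a 2.0-fold lower number from compound 1 to compound 2 (0.30 log units; within the scatter) stays within the scatter. The next change, to compound 3 `CC(=O)c1ccc(NC(=O)/C=C/C(=O)N2C/C(=C\c3ccc([N+](=O)[O-])cc3)C(=O)/C(=C/c3ccc([N+](=O)[O-])cc3)C2)cc1`, is 4-acetylphenyl in place of 3,4-dichlorophenyl on an amide-type nitrogen. Going by the values given here, the one measured step bearing on it, the aryl swap a 2.0-fold lower number from compound 1 to compound 2 (0.30 log units; within the scatter), was small, so no move beyond the scatter is expected, and the step to compound 3 is estimated as a 1.4-fold higher number from compound 2 to compound 3 (0.16 log units; within the scatter). Compound 3 is expected to give about 550 nM, in the range 220 nM to 1400 nM.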

Compound 3, half-maximal inhibitory concentration: 360 nM
Compound 3: middle estimate off by 1.5-fold (0.18 log units), on the high side, within the range that was stated.
By their numbers in this assay, from the lowest: compounds 3, 2 and 1 (each within the scatter of the next, the first and the last beyond it).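

In this assay the amide-type nitrogen takes 4-acetylphenyl as readily as 3,4-dichlorophenyl, with a 1.1-fold lower number from compound 2 to compound 3 (0.02 log units; within the scatter), so two aryl groups with different substituents and hydrogen-bond acceptor counts cannot be told apart here. Acetyl in place of methoxy on an aromatic carbon gives the first step in the set to pass the scatter, though only modestly, with a 2.1-fold lower number from compound 1 to compound 3 (0.32 log units; beyond the scatter). No evidence bears on the reason for either step. Still open, as far as these compounds go, is how an amine or a carboxylic acid on this aromatic ring would read, and whether an unsubstituted phenyl would stay in the same range.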